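Shortening the amine substituent on the shared core

This account rests on a few compounds, and the source may have more. Where it says the series, first, only, none or still open, it means among the compounds named here.

Compound 3 `COc1cc(N)c(Cl)cc1NC(=O)C1CCN(Cc2ccc(C)c(C)c2)CC1` sits only at a limit: in a functional assay on the whole organism for antagonist activity, with Mus musculus as the target (a lower number here means that less compound is needed, a higher number that more compound is needed for the effect), compound 3 gives > 8 mg/kg, which is a limit of the assay and not a number. Compound 1 `CCCN1CCC(C(=O)Nc2cc(Cl)c(N)cc2OC)CC1` also reaches only a limit, giving > 10 mg/kg in this assay. Compound 2 `COc1ccc(CN2CCC(C(=O)Nc3cc(Cl)c(N)cc3OC)CC2)cc1` gives 0.9 mg/kg in this assay. The steps show an at least 11-fold lower number from compound 1 to compound 2 (1.04 log units; beyond the scatter) and an at least 8.8-fold higher number from compound 2 to compound 3 (0.94 log units; beyond the scatter), while a step that the two limits leave unreadable from compound 1 to compound 3. Compound 4 `CCN1CCC(C(=O)Nc2cc(Cl)c(N)cc2OC)CC1` arises through (methyl in place of 3,4-dimethylphenyl on a saturated chain carbon bound to an amine nitrogen in a ring), the same difference cut one bond further out reading 3,4-dimethylbenzyl to ethyl. The closest comparison is compound 1 with its propyl, which gave only a limit, so no readable step is expected here: a step that the limit leaves unreadable from compound 3 to compound 4. In this assay compound 4 is estimated at 15 mg/kg, between 5 mg/kg and 50 mg/kg, most likely reported again as a limit.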

Compound 4, dose for half-maximal effect: > 10 mg/kg
Compound 4 ended at the assay's limit; the forecaster's own chance of this, stated with the estimate: 85%; the middle value does not contradict the limit.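

Compound 4 stands at a limit of this assay, not at a number, so ethyl reads no differently from the propyl of compound 1: the limit of > 10 mg/kg in this assay, at which 2 of the 4 values shown sit. Replacing 4-methoxyphenyl with methyl at this place gives an at least 11-fold higher number from compound 2 to compound 4 (1.04 log units; beyond the scatter) and confirms that compound 2 alone holds a readable value among the four. The steps to compound 4 from compound 3 and from compound 1 cannot be read. Going by these compounds, whether 4-chlorophenyl or 4-hydroxyphenyl at this place would match 4-methoxyphenyl stays open, as does how a butyl chain would read.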